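Swapping a Nitrile for an Acetamide on Two Related Cores

A few compounds are considered here, and "the series" means these few. Any claim that something is new, unique, unknown or untested is made for them only; others in the source may bear on it.

Compound 1, `Cc1cc(COc2cccc(C#N)c2)nc(-c2ccccn2)n1`, gives 2.7 in a physicochemical assay for lipophilicity, at pH 7.4; on this read-out higher numbers stand for higher lipophilicity and lower numbers for lower lipophilicity.
Compound 2, `Cc1cc(COc2ccc(C#N)cc2)nc(-c2ccccn2)n1`, gives 2.6 in this assay.
Compound 3, `CC(=O)Nc1cccc(OCc2cc(C)nc(-c3ccccn3)n2)c1`, gives 2.1 in this assay.

Compounds 1 and 2 contain the same atoms joined differently; the difference between the two cores is not broken down here, and their values in this assay lie within the scatter of each other. Compound 3 carries acetamido in place of cyano on an aromatic carbon, and this gave a number 0.60 log units lower from compound 1 to compound 3 (beyond the scatter).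

Compound 4, `CC(=O)Nc1ccc(OCc2cc(C)nc(-c3ccccn3)n2)cc1`, has not yet been measured. It carries acetamido in place of cyano on an aromatic carbon relative to compound 2. Among the compounds with values here, the change is the same kind as the one from compound 1 to compound 3, but the place differs: meta to a large group there, para to a large group here. Within the data shown here, a similar step of a number 0.60 log units lower from compound 2 to compound 4 (beyond the scatter) is expected, because a number 0.60 log units lower from compound 1 to compound 3 (beyond the scatter) is the only guide available. Compound 4 is therefore estimated at 2, between 1.7 and 2.4.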

Compound 4, distribution coefficient: 1.9
The estimate for compound 4 lay 0.10 log units above the measured number; measured number inside the range.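

In this assay acetamido in place of cyano on an aromatic carbon gave a number 0.70 log units lower from compound 2 to compound 4 (beyond the scatter) alongside a number 0.60 log units lower from compound 1 to compound 3 (beyond the scatter) on the other core, so the change carried across these two cores in the same direction and at a similar size. This is a single pair of cores, so it does not show that the step would hold on every core in the series. No measurement given here accounts for the size of either step.

The compounds shown leave open how other groups would behave in place of cyano, such as an amine, a carboxylic acid or a chain longer than acetamido. From the compounds shown here alone, whether any of these would follow the same step on both cores also remains unknown.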